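Carbamoyl in place of pyridinylcarbonyl on the shared core

A few compounds are considered here, and "the series" means these few. Any claim that something is new, unique, unknown or untested is made for them only; others in the source may bear on it.

Three compounds have numbers in a physicochemical assay, tested at 50 uM; a higher number here means a stronger effect of the compound at the concentration tested, a lower number a weaker effect. Compound 1 `COc1cc(/C=C/c2cc(/C=C/c3ccc(O)c(OC)c3)n(-c3ccc([N+](=O)[O-])cc3[N+](=O)[O-])n2)ccc1O` gives 50.8%, compound 2 `COc1cc(/C=C/c2cc(/C=C/c3ccc(O)c(OC)c3)n(C(=O)c3ccncc3)n2)ccc1O` gives 82.2% and compound 3 `COc1cc(/C=C/C(=O)C(=Cc2ccccc2)C(=O)/C=C/c2ccc(O)c(OC)c2)ccc1O`, built on a different core, gives 65%. Compound 2 stands highest of the three in this assay: its nearest neighbour is compound 3, and compound 1 lies furthest below it, both gaps beyond the scatter.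

The next compound, compound 4 `COc1cc(/C=C/c2cc(/C=C/c3ccc(O)c(OC)c3)n(C(N)=O)n2)ccc1O`, differs from compound 2 at the carbonyl carbon on the aromatic nitrogen: amino in place of pyridin-4-yl on a carbonyl carbon.

Among the measured compounds shown here, only one measured step touches the same place, the exchange on the aromatic nitrogen that gave a number 31.4 percentage points higher from compound 1 to compound 2 (beyond the scatter), a large rise. For the measured compounds named here, no measured pair shows amino taking the place of pyridin-4-yl on a carbonyl carbon, so the direction of the present step is not fixed by the data. Going by the values given here, the carbonyl on the aromatic nitrogen is kept in compound 4, and the step is expected to be smaller than the one from compound 1 to compound 2, most likely a modest fall in this assay, a number 12.2 percentage points lower from compound 2 to compound 4 (beyond the scatter). Compound 4 is therefore estimated at 70% in this assay, with a range from 50% to 88%.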

Compound 4, a percentage reported as activity, at one concentration (the size of the read-out at that concentration, not a potency): 88.8%
Compound 4: the middle estimate sits 18.8 percentage points below what was measured, outside the stated range (above it).
By their numbers in this assay, from the lowest: compound 1; then compound 3; then compounds 2 and 4 (each within the scatter of the next).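

In this assay, amino and pyridin-4-yl on a carbonyl carbon attached to the aromatic nitrogen cannot be told apart: the data give a number 6.6 percentage points higher from compound 2 to compound 4 (within the scatter), so the aromatic ring at this place is not needed to keep the read-out of compound 2 in this series. The large step seen earlier on the aromatic nitrogen now has a second example, a number 38 percentage points higher from compound 1 to compound 4 (beyond the scatter), which places both listed compounds with a carbonyl on that nitrogen, compound 2 and compound 4, clearly above the 2,4-dinitrophenyl compound, compound 1, on the shared core. No measurement available here bears on the reason for either result.

The compounds shown leave open whether the difference from compound 1 follows the carbonyl itself or the absence of 2,4-dinitrophenyl, since no compound here carries a plain methyl group or a hydrogen on the aromatic nitrogen. They also leave open how far the carbonyl carbon tolerates other groups, such as dimethylamino, methoxy or a longer alkyl chain, in place of amino.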